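Phenol-Bearing Benzylamine in Place of Hydroxymethyl

A few compounds are considered here, and "the series" means these few. Any claim that something is new, unique, unknown or untested is made for them only; others in the source may bear on it.

Of the compounds shown here, three sharing one core have been tested in a functional assay on HCT-116 cells (Homo sapiens) for inhibition, read by MTT assay, with a stated time of 72 h; on this read-out higher numbers stand for weaker inhibition and lower numbers for stronger inhibition. Compound 3 `COc1cc(Oc2cccc(Nc3ccccc3)c2)cc(OC)c1CCO` gives > 20000 nM, which is a limit of the assay and not a number. Compound 1 `COc1cc(Oc2cccc(Nc3ccccc3)c2)cc(OC)c1CN[C@H](C)c1ccccc1` likewise gives > 20000 nM, again a limit. Going by the values given here, compound 2 `COc1cc(Oc2cccc(Nc3ccccc3)c2)cc(OC)c1CN(C)C` gives 12900 nM, the only plain number of the three. Among the compounds with values here, the step of an at least 1.5-fold higher number from compound 2 to compound 3 (0.19 log units; that floor lies within the scatter) is the sole readable change and lies within the scatter, while the step that the two limits leave unreadable from compound 1 to compound 3 cannot be sized, as the limit of > 20000 nM in this assay, at which 2 of the 3 values shown sit, shows. The next compound, compound 4 `COc1cc(Oc2cccc(Nc3ccccc3)c2)cc(OC)c1CNCc1ccc(O)cc1`, differs from compound 3 in one place: (4-hydroxybenzyl)amino in place of hydroxymethyl on a saturated chain carbon bound to an aromatic carbon. Compound 1 also carries an amine with an aromatic ring on that chain carbon and shows only a limit. With that in view, the step of an at least 1.1-fold lower number from compound 3 to compound 4 (0.04 log units; that floor lies within the scatter) is expected to be small, in no clear direction. Compound 4 is estimated at 18000 nM, within 7000 nM to 40000 nM, with a fair chance that only a limit is reported.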

Compound 4, half-maximal inhibitory concentration: 3360 nM
Compound 4: middle estimate off by 5.4-fold (0.73 log units), on the high side, outside the stated range (below it).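

In this assay, going by these compounds alone, this chain carbon gives the first change beyond the scatter, with (4-hydroxybenzyl)amino producing an at least 5.9-fold lower number from compound 3 to compound 4 (0.77 log units; beyond the scatter). Within the data shown here, the same group gives a 3.8-fold lower number from compound 2 to compound 4 (0.58 log units; beyond the scatter), and as this is the one step here between two plain numbers, the drop does not depend on a limit alone. An aromatic ring on the amine is not enough by itself, since the change on the amine nitrogen gives an at least 5.9-fold lower number from compound 1 to compound 4 (0.77 log units; beyond the scatter), and this size and that of the step from compound 3 are only floors set by a limit: the limit of > 20000 nM in this assay, at which 2 of the 4 values shown sit.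

Still open, from the compounds shown here alone, is whether the ring hydroxyl or the loss of the branching methyl matters more, as 4-hydroxybenzyl and 1-phenylethyl differ in both. A plain benzylamino group would help to separate the two, and a 4-methoxybenzylamino group would test the hydroxyl itself.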